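Swapping a sulfone for a sulfonamide: solubility outlook

This account rests on a few compounds, and the source may have more. Where it says the series, first, only, none or still open, it means among the compounds named here.

Compound 2 `CNc1nc(NCCCN(C)C)c2sc(-c3ccc(S(C)(=O)=O)cc3)cc2n1` carries a methylsulfonyl group on its outer aromatic ring. In a physicochemical assay for solubility, at pH 2 (a lower number here means a less soluble compound, a higher number a more soluble compound), compound 2 gives > 100 ug/mL, which is a limit of the assay rather than a number. Its closest relative, compound 1 `CNc1nc(NCCCN(C)C)c2sc(-c3ccc(N)cc3)cc2n1`, bears an amino group at that same position. In this assay compound 1 gives > 100 ug/mL, again a limit. The change between them, a step that the two limits leave unreadable from compound 1 to compound 2, therefore cannot be sized, because of the limit of > 100 ug/mL in this assay, at which 2 of the 2 values shown sit. Compound 3 `CNc1nc(NCCCN(C)C)c2sc(-c3ccc(NS(C)(=O)=O)cc3)cc2n1` is the next variation: methanesulfonamido in place of methylsulfonyl on an aromatic carbon. Within the data shown here, only that one unreadable step bears on this change, so the data set no direction; the expectation is that compound 3 also reaches the limit in this assay, an expected step that the limit leaves unreadable from compound 2 to compound 3 of no readable size. Compound 3 is accordingly estimated at 150 ug/mL, within a range from 60 ug/mL to 400 ug/mL.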

Compound 3, solubility: > 100 ug/mL
Compound 3 gave a limit, no number; the forecaster's own chance of this, stated with the estimate: 80%; the middle value is on the limit's open side.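

No step among compound 1, compound 2 and compound 3 can be read in this assay, since all three stop at the same limit: the limit of > 100 ug/mL in this assay, at which 3 of the 3 values shown sit.

As far as these compounds go, whether the amino, methylsulfonyl and methanesulfonamido groups give different solubilities stays open, as does how far each compound lies beyond that limit.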